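The source may report more compounds than this note shows. Statements on the series, on what has been measured and on what is new or still open speak of the compounds shown alone.

Among the compounds with values here, compound 2 `Nc1ncnc2c1ccn2-c1ccc(NC(=O)c2cccc(C(F)(F)F)c2)cc1` gives 9700 nM in a functional assay on A375P cells (Homo sapiens) for antiproliferative activity, read by MTT assay, with a stated time of 24 h (on this read-out higher numbers stand for weaker inhibition and lower numbers for stronger inhibition), the higher of the two numbers measured so far. Compound 1 `O=C(Nc1ccc(-n2ccc3c(NC(=O)c4ccccc4)ncnc32)cc1)c1cc(C(F)(F)F)cc(C(F)(F)F)c1` gives 2000 nM, a number that lies beyond the scatter below that of compound 2. Compound 3 `O=C(Nc1ccc(-n2ccc3c(NC(=O)c4ccccc4)ncnc32)cc1)c1cccc(C(F)(F)F)c1` is derived from compound 2 by a single change: benzoyl in place of hydrogen on a nitrogen on an aromatic ring, so the amino group becomes a benzamido group, the same group that compound 1 carries on its core. In this assay the expected step is a 2.8-fold lower number from compound 2 to compound 3 (0.44 log units; beyond the scatter), a lowering beyond the scatter toward stronger inhibition. Compound 3 is accordingly expected at 3500 nM, within a range of 1500 nM to 8000 nM.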

Compound 3, half-maximal inhibitory concentration: 4700 nM
Compound 3: middle estimate off by 1.3-fold (0.13 log units), on the low side; the range from low to high includes it.
By their numbers in this assay, from the lowest: compound 1; then compound 3; then compound 2.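

In this assay, amino to benzamido on the shared core gives a 2.1-fold lower number from compound 2 to compound 3 (0.31 log units; beyond the scatter), so this nitrogen tolerates the added benzoyl with a modest gain. With benzamido in place, hydrogen in place of trifluoromethyl on an aromatic carbon gives a 2.4-fold higher number from compound 1 to compound 3 (0.37 log units; beyond the scatter), separating a modest contribution of that trifluoromethyl from the benzoyl step, which compounds 1 and 2 alone could not do. Nothing shown gives a cause for either step.

Open, as far as these compounds go, is how acetyl or a longer acyl chain would compare with benzoyl on this nitrogen. Also open, from the compounds shown here alone, is whether an amine or a carboxylic acid on the benzoyl ring would move the number further.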